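From fluoro to iodo on the aromatic ring

The source may report more compounds than this note shows. Statements on the series, on what has been measured and on what is new or still open speak of the compounds shown alone.

Compound 1 `CC(=NNC(=S)Nc1ccccc1F)c1ccccn1` gives 5 nM
Compound 2 `C/C(=N/NC(=S)Nc1ccccc1F)c1ccccn1` gives 5 nM
Compound 3 `C/C(=N\NC(=S)Nc1ccccc1F)c1ccccn1` gives 5 nM

In a functional assay on U-87MG ATCC cells (Homo sapiens) for cytotoxicity, read by MTT assay, with a stated time of 48 h (a lower number here means a stronger inhibitor, a higher number a weaker inhibitor), compound 2 gives 5 nM and stands level with compounds 1 and 3. Compound 4 `C/C(=N/NC(=S)Nc1ccccc1I)c1ccccn1` carries iodo in place of fluoro on an aromatic carbon, ortho to a large group, a change counted as iodo in place of fluoro on an aromatic carbon and not yet measured. The measured steps of no change at the digits printed from compound 1 to compound 2 (within the scatter) and no change at the digits printed from compound 1 to compound 3 (within the scatter) and no change at the digits printed from compound 2 to compound 3 (within the scatter) concern only the configuration of a double bond, so none of them tests this swap. They offer neither a size nor a direction for it, so the expectation is no shift beyond the scatter, held with a wide margin. The estimated step of no change at the digits printed from compound 2 to compound 4 (within the scatter) is only a cautious expectation. Compound 4 is expected at 5 nM with 1.5 nM to 25 nM as its estimated range.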

Compound 4, half-maximal inhibitory concentration: 6.1 nM
For compound 4 the middle estimate is 1.2-fold (0.09 log units) below the measured one; the range from low to high includes it.
By their numbers in this assay, from the lowest: compounds 1, 2, 3 and 4 (each within the scatter of the next).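

In this assay, among the compounds shown here, there is a 1.2-fold higher number from compound 2 to compound 4 (0.09 log units; within the scatter) with iodo in place of fluoro on an aromatic carbon, the first measured change of the group itself rather than of a double bond's configuration. At this position, then, the larger halogen leaves the number within the scatter. Nothing measured here bears on why fluoro and iodo read alike.

Two halogens alone do not show how much this position tolerates, and an amine, a carboxylic acid or a longer chain in that place remains an open question.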